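Lengthening the amide chain: compound 3 to compound 4

A few compounds are considered here, and "the series" means these few. Any claim that something is new, unique, unknown or untested is made for them only; others in the source may bear on it.

Measured so far in a functional assay on K562 cells (Homo sapiens) for antiproliferative activity, read by CCK-8 assay, with a stated time of 72 h; on this read-out higher numbers stand for weaker inhibition of growth and lower numbers for stronger inhibition of growth:
- compound 1 `CCC1C(=O)N(C)c2cnc(-n3ccc4cc(C(=O)NC)ccc43)nc2N1c1ccn(C)n1` gives 13300 nM
- compound 2 `CCC1C(=O)N(C)c2cnc(-n3ccc4cc(F)ccc43)nc2N1c1ccn(C)n1` gives 6070 nM
- compound 3 `CCNC(=O)c1ccc2c(ccn2-c2ncc3c(n2)N(c2ccn(C)n2)C(CC)C(=O)N3C)c1` gives 12800 nM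

Compound 3 shares the high end of these numbers with compound 1, and only compound 2 stands clearly lower. Compound 4 `CCC1C(=O)N(C)c2cnc(-n3ccc4cc(C(=O)NCC(C)C)ccc43)nc2N1c1ccn(C)n1` carries isobutylcarbamoyl in place of ethylcarbamoyl, with isopropyl in place of methyl on a saturated chain carbon bound to an amide-type nitrogen as the counted difference. For the measured compounds named here, the nearest precedent is the earlier growth of this amide chain, with a 1.0-fold lower number from compound 1 to compound 3 (0.02 log units; within the scatter) as its only measured case. The exchanges with fluoro are larger, at a 2.2-fold lower number from compound 1 to compound 2 (0.34 log units; beyond the scatter) and a 2.1-fold higher number from compound 2 to compound 3 (0.32 log units; beyond the scatter), but they replace the whole group and bear on this change only loosely. No step beyond the scatter is therefore expected in this assay, and the estimated step is a 1.0-fold higher number from compound 3 to compound 4 (0.01 log units; within the scatter) as a working figure. For compound 4 the estimated value is 13000 nM with an expected range of 5500 nM to 30000 nM in this read-out.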

Compound 4, concentration for 50% growth inhibition: 5600 nM
The estimate for compound 4 lay 2.3-fold (0.37 log units) above the measured number; the range from low to high includes it.
By their numbers in this assay, from the lowest: compounds 4 and 2 (each within the scatter of the next); then compounds 3 and 1 (each within the scatter of the next).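

In this assay the amide chain now makes a difference, with a 2.3-fold lower number from compound 3 to compound 4 (0.36 log units; beyond the scatter) on going from ethylcarbamoyl to isobutylcarbamoyl, whereas the earlier growth of this chain gave only a 1.0-fold lower number from compound 1 to compound 3 (0.02 log units; within the scatter). Against the smallest amide the change gives a 2.4-fold lower number from compound 1 to compound 4 (0.38 log units; beyond the scatter), while a 1.1-fold lower number from compound 2 to compound 4 (0.04 log units; within the scatter) leaves isobutylcarbamoyl and fluoro indistinguishable on this read-out. No measurement at hand accounts for the step.

As far as these compounds go, whether the response depends on the branch of the isobutyl group or on chain length alone stays open. A longer chain, or one ending in an amine, would bear on this.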